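Ether Chain Variation in a Lipoxygenase Inhibitor Series

This account rests on a few compounds, and the source may have more. Where it says the series, first, only, none or still open, it means among the compounds named here.

Measured compounds:
compound 1 `CCOCC1CN(c2ccccc2)NC1=O`: 280 nM
compound 2 `CCCOCC1CN(c2ccccc2)NC1=O`: 260 nM

In an assay on isolated protein for inhibition of Polyunsaturated fatty acid 5-lipoxygenase (Rattus norvegicus) (on this read-out lower numbers stand for stronger inhibition and higher numbers for weaker inhibition), compound 2 gives 260 nM, the lowest of the two numbers, but its nearest neighbour is compound 1 at 280 nM, and the step of a 1.1-fold lower number from compound 1 to compound 2 (0.03 log units; within the scatter) is within the scatter, so the two compounds cannot be ordered. Compound 3 `COCCOCC1CN(c2ccccc2)NC1=O` is not yet measured; it differs from compound 2 by methoxy in place of methyl on a saturated chain carbon, two bonds along the chain from an oxygen on a saturated carbon. Going by the values given here, only one measured step bears on this change: a 1.1-fold lower number from compound 1 to compound 2 (0.03 log units; within the scatter), which also altered the end of the same ether chain and left the number where it was. On that basis the step of a 1.2-fold higher number from compound 2 to compound 3 (0.06 log units; within the scatter) is expected to be small, with no shift beyond the scatter foreseen in either direction. Compound 3 is therefore estimated at 300 nM, with a range of 120 nM to 750 nM.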

Compound 3, half-maximal inhibitory concentration: 520 nM
Compound 3: the middle estimate sits 1.7-fold (0.24 log units) below what was measured; measured number inside the range.
By their numbers in this assay, from the lowest: compounds 2, 1 and 3 (each within the scatter of the next).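

Going by these compounds alone, with compound 3, the end of the ether chain carries an oxygen for the first time, as the change from propoxy to 2-methoxyethoxy brings in one hydrogen-bond acceptor, whereas the earlier pair differed only by a methyl in place of a hydrogen. In this assay, within the data shown here, this gives a 2.0-fold higher number from compound 2 to compound 3 (0.30 log units; within the scatter) and a 1.9-fold higher number from compound 1 to compound 3 (0.27 log units; within the scatter), so even with this oxygen in the chain, no step at this position goes beyond the scatter and the three compounds cannot be ordered. Nothing measured here explains these numbers.

The compounds shown leave open whether an amine, a carboxylic acid or a longer chain at this place would move the number beyond the scatter. They also leave open whether methoxy in place of methyl at this place would give a similar step on a different core.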